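From Trifluoromethyl to Cyano: Expecting Compound 4

The source may hold more compounds than are shown below. What is called first, only, known or untested is meant among the compounds shown, and "the series" means these compounds.

Three compounds sharing one core have been tested in a functional assay on the whole organism (integument) for inhibition, with Chilo suppressalis as the target, read by scintillation counting, with a stated time of 72 h; a lower number here means a stronger inhibitor, a higher number a weaker inhibitor:
Compound 1, `COc1cccc(OC)c1C(=O)Nc1nnc(-c2ccccc2)s1`, gives 2950 nM.
Compound 2, `COc1cccc(OC)c1C(=O)Nc1nnc(-c2ccc(C(C)(C)C)cc2)s1`, gives 912 nM.
Compound 3, `COc1cccc(OC)c1C(=O)Nc1nnc(-c2ccc(C(F)(F)F)cc2)s1`, gives 49 nM.

Compound 3 stands lowest of the three, which in this assay means the strongest inhibitor of the set; its steps to both others lie beyond the scatter. Replacing the hydrogen of compound 1 gave a 3.2-fold lower number from compound 1 to compound 2 (0.51 log units; beyond the scatter) and a 60-fold lower number from compound 1 to compound 3 (1.78 log units; beyond the scatter), and exchanging one group for the other gave a 19-fold lower number from compound 2 to compound 3 (1.27 log units; beyond the scatter). Every group placed at this spot so far has lowered the number, and trifluoromethyl did so by far the most.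

Compound 4, `COc1cccc(OC)c1C(=O)Nc1nnc(-c2ccc(C#N)cc2)s1`, carries a new group at the same spot: cyano in place of trifluoromethyl on an aromatic carbon. For the measured compounds named here, no measured pair involves a cyano group, so the three steps above only bracket what could happen: the spot clearly tolerates substitution, yet the size of the gain varies strongly with the group, as the gap between tert-butyl and trifluoromethyl shows. A cyano group is expected to keep part but not all of that gain, so a step of a 4.1-fold higher number from compound 3 to compound 4 (0.61 log units; beyond the scatter) is estimated. Compound 4 is therefore expected to give about 200 nM, within a range from 50 nM to 900 nM.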

Compound 4, half-maximal inhibitory concentration: 209 nM
For compound 4 the middle estimate is 1.0-fold (0.02 log units) below the measured one; low and high end bracket the measured number.
By their numbers in this assay, from the lowest: compound 3; then compound 4; then compound 2; then compound 1.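

In this assay, cyano takes a middle place among the groups at this spot: the change gives a 4.3-fold higher number from compound 3 to compound 4 (0.63 log units; beyond the scatter), so part of the gain seen with trifluoromethyl is lost. Much of that gain remains, however, as the steps of a 4.4-fold lower number from compound 2 to compound 4 (0.64 log units; beyond the scatter) and a 14-fold lower number from compound 1 to compound 4 (1.15 log units; beyond the scatter) show, so a strong lowering of the number is not confined to trifluoromethyl and the spot now has a clear order of four groups, with trifluoromethyl first, then cyano, tert-butyl and hydrogen. Cyano has fewer heavy atoms than trifluoromethyl and brings one hydrogen-bond acceptor where trifluoromethyl has none, but no measurement of any property of these compounds is available to connect either difference with the result.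

The compounds shown leave open where other groups, such as a chlorine atom, a methoxy group, an amine or a carboxylic acid, would fall in this order at the same spot. They also leave open whether the same order would hold if another part of the shared core were changed, for instance if the two methoxy groups gave way to ethoxy groups.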